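Acyl Substitution on the Amine of the Long-Chain Amides

The compounds below may be only part of what the source reports. "The series", "measured", "known", "first", "only" and "open" are said of these compounds alone.

Compound 1 `CCCCCCCCCCCCCCNC(=O)[C@@H](N)[C@@H](C)O` carries a free amine on the shared core and holds the lowest of the two numbers in a functional assay on A-431 cells (Homo sapiens) for cytotoxicity, read by MTT assay, with a stated time of 48 h (on this read-out lower numbers stand for stronger inhibition and higher numbers for weaker inhibition), where compound 1 gives 14600 nM. Compound 2 `CCCCCCCCCCCCCCCCCCNC(=O)[C@@H](N)[C@@H](C)O` differs only by a longer chain; in this assay compound 2 gives 21300 nM, and the step of a 1.5-fold higher number from compound 1 to compound 2 (0.16 log units; within the scatter) stays within the scatter. Compound 3 `CCCCCCCCCCCCNC(=O)[C@@H](NC(=O)/C=C/c1ccccc1)[C@@H](C)O` carries an acyl group on the amine nitrogen together with a shorter chain; in this assay compound 3 gives only a limit, > 200000 nM, which is the limit of > 200000 nM in this assay, at which 1 of the 3 values shown sits.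

Compound 4 `CCCCCCCCCCCCCCNC(=O)[C@@H](NC(=O)c1cccs1)[C@@H](C)O` is reached from compound 1 by (thiophen-2-yl)carbonyl in place of hydrogen on an amine nitrogen. Within the data shown here, the only measured step, a 1.5-fold higher number from compound 1 to compound 2 (0.16 log units; within the scatter), concerns chain length and does not touch the amine nitrogen, so no measured step bears directly on this change. Among the measured compounds shown here, compound 3 is the one compound with an acyl group on that nitrogen, and it reads as a limit rather than a number.

Compound 4 is therefore expected to give 60000 nM, within 15000 nM to 200000 nM, an expected step of a 4.1-fold higher number from compound 1 to compound 4 (0.61 log units; beyond the scatter) towards weaker inhibition, with a fair chance that only a limit is reported.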

Compound 4, half-maximal inhibitory concentration: 26500 nM
For compound 4 the middle estimate is 2.3-fold (0.35 log units) above the measured one; measured number inside the range.
By their numbers in this assay, from the lowest: compounds 1, 2 and 4 (each within the scatter of the next). At a limit, above all of these: compound 3.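

In this assay, a change on the amine nitrogen now has a measured step: (thiophen-2-yl)carbonyl in place of hydrogen reads as a 1.8-fold higher number from compound 1 to compound 4 (0.26 log units; within the scatter). At the chain of compound 1, a free amine on the shared core is thus not needed for a measured number, and this acyl group leaves the read-out within the scatter. Compound 3 differs from compound 4 in both the acyl group and the chain, so the two cannot be compared, and the value of compound 3 is only a limit: the limit of > 200000 nM in this assay, at which 1 of the 4 values shown sits.

The compounds shown do not separate the acyl group of compound 3 from its shorter chain. Also open, from the compounds shown here alone, is how an acetyl or benzoyl group on this nitrogen, or a longer chain on the thiophene amide, would read.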